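Chain branching on the dimethylpyridyloxy analogue of the series

The source may hold more compounds than are shown below. What is called first, only, known or untested is meant among the compounds shown, and "the series" means these compounds.

Measured in a functional assay on CHO cells for positive allosteric modulation of metabotropic glutamate receptor 2 (Homo sapiens), read by scintillation counting and GTPgammaS binding, with a stated time of 30 min; on this read-out lower numbers stand for an effect already at smaller amounts and higher numbers for an effect only at larger amounts of compound:
Compound 1, `CC(C)CCn1ccc(-c2ccc(Oc3ccccn3)cc2)c(C#N)c1=O`: compound 1 gives 646 nM.
Compound 2, `CC(C)CCn1ccc(-c2ccc(Oc3ccncc3)cc2)c(C#N)c1=O`: compound 2 gives 550 nM.
Compound 3, `CCCCn1ccc(-c2ccc(Oc3ccc(C)nc3C)cc2)c(C#N)c1=O`: compound 3 gives 138 nM.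

Compound 3 stands lowest of the three numbers, beyond the scatter from both compound 2 and compound 1. Compound 4, `Cc1ccc(Oc2ccc(-c3ccn(CCC(C)C)c(=O)c3C#N)cc2)c(C)n1`, differs from compound 3 by methyl in place of hydrogen on a saturated chain carbon bound to two saturated chain carbons. Among the compounds with values here, the only measured step, a 1.2-fold lower number from compound 1 to compound 2 (0.07 log units; within the scatter), concerns the aryl ether and not the chain. Within the data shown here, no measured pair differs in the chain alone: compounds 1 and 2 carry the longer branched chain together with a different pyridyl, so the step to compound 4 has no direct precedent here. In this assay a change within the scatter is therefore expected, a 1.1-fold lower number from compound 3 to compound 4 (0.03 log units; within the scatter). Compound 4 is estimated at 130 nM, in the range 55 nM to 310 nM.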

Compound 4, half-maximal effective concentration: 100 nM
The estimate for compound 4 lay 1.3-fold (0.11 log units) above the measured number; low and high end bracket the measured number.
By their numbers in this assay, from the lowest: compounds 4 and 3 (each within the scatter of the next); then compounds 2 and 1 (each within the scatter of the next).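

In this assay, the change from butyl to isopentyl, methyl in place of hydrogen on a saturated chain carbon bound to two saturated chain carbons, stays within the scatter (a 1.4-fold lower number from compound 3 to compound 4 (0.14 log units; within the scatter)). With the isopentyl chain held constant, 2,6-dimethylpyridin-3-yl on the oxygen gives lower numbers than either plain pyridyl (a 5.5-fold lower number from compound 2 to compound 4 (0.74 log units; beyond the scatter); a 6.5-fold lower number from compound 1 to compound 4 (0.81 log units; beyond the scatter)). No measurement shown explains either result.

Open, going by these compounds, is whether a longer chain such as hexyl, or an amine or carboxylic acid at the chain end, would fit this position. Also open, on these data alone, is how each methyl of the 2,6-dimethylpyridin-3-yl group contributes.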